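This account rests on a few compounds, and the source may have more. Where it says the series, first, only, none or still open, it means among the compounds named here.

Compound 1 `Cc1ccc(S(=O)(=O)N[C@@H](CC(=O)NC(C)(C)C)C(=O)NCCNC(=O)c2cccc(O)c2)cc1` and compound 2 `Cc1ccc(S(=O)(=O)N[C@@H](CC(=O)NC(C)(C)C)C(=O)NCCNC(=O)c2cccc(C#N)c2)cc1` share one core and differ in a single group on an aromatic carbon. In an ADME assay on Karpas-1106P cells (Homo sapiens) for cytotoxicity (on this read-out higher numbers stand for an effect only at larger amounts of compound and lower numbers for an effect already at smaller amounts), compound 1 gives only a limit of the assay, > 11100 nM. In this assay compound 2 likewise gives only a limit, > 11100 nM. The change from compound 1 to compound 2, cyano in place of hydroxy on an aromatic carbon, is therefore a step whose size cannot be read: a step that the two limits leave unreadable from compound 1 to compound 2. Both values sit at the same limit, (the limit of > 11100 nM in this assay, at which 2 of the 2 values shown sit). Compound 3 `Cc1ccc(S(=O)(=O)N[C@@H](CC(=O)NC(C)(C)C)C(=O)NCCNC(=O)c2ccc(F)c(F)c2)cc1` is not yet measured; it differs from compound 2 by 3,4-difluorophenyl in place of 3-cyanophenyl on a carbonyl carbon. For the measured compounds named here, no measured step bears on this change, and the only two values shown are limits, so no step beyond the scatter can be predicted in either direction. Compound 3 is therefore expected to sit at the same limit, an estimate of 15000 nM with a range from 8000 nM to 40000 nM, meaning an expected step that the limit leaves unreadable from compound 2 to compound 3.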

Compound 3, half-maximal effective concentration: > 11100 nM
Compound 3: a limit, no number (the forecaster's own chance of this, stated with the estimate: 80%); the middle value lies beyond the limit too.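

In this assay compound 3 also gives only a limit, > 11100 nM. For the compounds shown here, no step among compound 1, compound 2 and compound 3 can be read, since all three sit at one limit: the limit of > 11100 nM in this assay, at which 3 of the 3 values shown sit. As far as these compounds go, whether swapping these aromatic groups changes the cytotoxicity read-out at all stays open.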